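Cyclopentyl for Phenyl on the Chain of Compound 3

The compounds below may be only part of what the source reports. "The series", "measured", "known", "first", "only" and "open" are said of these compounds alone.

Measured compounds: compound 1 `CCCc1n[nH]c2c(=O)n(NC(=O)c3ccccc3)c(-c3cccc(OC)c3)nc12` gives 23.6%; compound 2 `COc1cccc(-c2nc3c(-c4ccc(Cl)cc4)n[nH]c3c(=O)n2NC(=O)c2ccccc2)c1` gives 94.1%; compound 3 `O=C(Nn1c(CCc2ccccc2)nc2c(-c3ccc(Cl)cc3)n[nH]c2c1=O)c1ccccc1` gives 85.6%.

In a functional assay on DU-145 cells (Homo sapiens) for cytotoxicity, read by sulforhodamine B assay, with a stated time of 2 days, tested at 100 uM (on this read-out lower numbers stand for less inhibition and higher numbers for more inhibition at the one concentration tested (going by the name of the read-out)), compound 3 stands second highest of the three. Its nearest neighbour is compound 2, a value within the usual scatter of it, while compound 1 lies far lower. Compound 4 `O=C(Nn1c(CCC2CCCC2)nc2c(-c3ccc(Cl)cc3)n[nH]c2c1=O)c1ccccc1` differs from compound 3 by cyclopentyl in place of phenyl on a saturated chain carbon, two bonds along the chain from an aromatic carbon. Both compounds keep the 4-chlorophenyl that a number 70.5 percentage points higher from compound 1 to compound 2 (beyond the scatter) brought in. The step that touches the same part of the molecule is a number 8.5 percentage points lower from compound 2 to compound 3 (within the scatter), which hardly moved the number. Exchanging phenyl for cyclopentyl at the end of a retained chain is therefore expected to change little, and a number 5.6 percentage points lower from compound 3 to compound 4 (within the scatter) is the estimated step. Compound 4 is expected to give 80%, within 60% to 95%.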

Compound 4, a percentage reported as inhibition, at one concentration (the size of the read-out at that concentration, not a potency): 89.6%
Compound 4: the middle estimate sits 9.6 percentage points below what was measured; the range from low to high includes it.
By their numbers in this assay, from the lowest: compound 1; then compounds 3, 4 and 2 (each within the scatter of the next).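

In this assay, an aromatic ring at the end of the chain is not required at this place: a number 4 percentage points higher from compound 3 to compound 4 (within the scatter) shows that a non-aromatic cyclopentyl ring cannot be told apart from phenyl. Nor can the whole 2-cyclopentylethyl group be told apart from 3-methoxyphenyl on the aromatic carbon, with a number 4.5 percentage points lower from compound 2 to compound 4 (within the scatter) as the step. No other measurement on these compounds bears on this result. As far as these compounds go, whether any ring is needed at the chain end remains open, and a terminal amine or a plain butyl chain would test this. A single concentration also leaves potency differences among these three compounds unresolved.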